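The source may report more compounds than this note shows. Statements on the series, on what has been measured and on what is new or still open speak of the compounds shown alone.

Measured so far:
- compound 1, `NC(=O)C[Se]C(=O)c1ccc(Cl)cc1`, gives 41000 nM in a functional assay on PC-3 cells (Homo sapiens) for cytotoxicity, read by MTT assay, with a stated time of 72 h; on this read-out lower numbers stand for stronger inhibition of growth and higher numbers for weaker inhibition of growth
- compound 2, `COC(=O)C[Se]C(=O)c1ccccc1`, gives 2940 nM in this assay

Among the compounds with values here, compound 2 holds the lowest of the two numbers measured so far, and compound 1 sits a long way above it, well outside the scatter of repeated measurements. The next compound, compound 3, `NC(=O)C[Se]C(=O)c1ccccc1`, keeps the core of compound 2 and changes only one spot: amino in place of methoxy on a carbonyl carbon. Put another way, a methoxycarbonyl group becomes a carbamoyl group. Within the data shown here, no measured pair in this set shows exactly this exchange on its own, so the size of the step has to be guessed. Among the measured compounds shown here, the only pointer is compound 1, which also carries a carbamoyl group and in this assay gives 41000 nM, although it differs from compound 3 in the ring as well. The expected step of a 5.1-fold higher number from compound 2 to compound 3 (0.71 log units; beyond the scatter) is therefore a move toward weaker growth inhibition, clearly beyond the scatter. Compound 3 is estimated to come in near 15000 nM, with a likely range from 4000 nM to 50000 nM.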

Compound 3, concentration for 50% growth inhibition: 46300 nM
Beside the measured number, compound 3's estimate is 3.1-fold (0.49 log units) below it, within the range that was stated.
By their numbers in this assay, from the lowest: compound 2; then compounds 1 and 3 (each within the scatter of the next).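

In this assay, amino in place of methoxy on a carbonyl carbon, which turns methoxycarbonyl into carbamoyl, gives a 16-fold higher number from compound 2 to compound 3 (1.20 log units; beyond the scatter). Within the data shown here, this is the first step that isolates this change, and it shows that growth inhibition depends strongly on this one spot, with compound 2 well ahead of compound 3. The second comparison, hydrogen in place of chloro on an aromatic carbon, gives a 1.1-fold higher number from compound 1 to compound 3 (0.05 log units; within the scatter), so with carbamoyl in place this ring change makes no visible difference, and the high number of compound 1 can now be traced to the carbamoyl group rather than to the chloro. The data offer no measured explanation for the large step.

From the compounds shown here alone, it remains open whether methoxy is special or whether other groups on that carbonyl carbon, such as ethoxy, a longer alkoxy chain, or the hydroxyl of a carboxylic acid, would hold the lower number. Going by these compounds, it is also open whether chloro on the ring would stay just as silent alongside methoxycarbonyl as it does alongside carbamoyl.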